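Hydroxy on the phenyl of compound 3

A few compounds are considered here, and "the series" means these few. Any claim that something is new, unique, unknown or untested is made for them only; others in the source may bear on it.

Compound 1 `COc1ccc2c(COC(=O)C=C(C)C)cc(=O)oc2c1`: > 10 ug/mL
Compound 2 `C=CC(=O)OCc1cc(=O)oc2cc(OC)c(OC)cc12`: > 10 ug/mL
Compound 3 `COc1cc2oc(=O)cc(COC(=O)/C=C/c3ccccc3)c2cc1OC`: > 10 ug/mL

Compound 3 has only a limit in a functional assay on HCT-116 cells (Homo sapiens) for inhibition (a higher number here means a weaker inhibitor, a lower number a stronger inhibitor), > 10 ug/mL, and no number is known for it. For the measured compounds named here, the series so far shows (the limit of > 10 ug/mL in this assay, at which 3 of the 3 values shown sit). Compound 4 `COc1cc2oc(=O)cc(COC(=O)/C=C/c3ccc(O)cc3)c2cc1OC` differs from compound 3 by hydroxy in place of hydrogen on an aromatic carbon, turning phenyl to 4-hydroxyphenyl. Going by the values given here, the one measured step that bears on this, a step that the two limits leave unreadable from compound 2 to compound 3, has no readable size and gives no guide to size or direction. No shift beyond the scatter can therefore be forecast in this assay, and a further limit is the likeliest report. The expected step is a step that the limit leaves unreadable from compound 3 to compound 4, with no supported direction. For compound 4 the estimate is 15 ug/mL, expected within 5 ug/mL to 40 ug/mL.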

Compound 4, half-maximal inhibitory concentration: 5.21 ug/mL
Compound 4: the middle estimate sits 2.9-fold (0.46 log units) above what was measured; the measured number falls inside the stated range.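

In this assay, hydroxy in place of hydrogen, turning phenyl to 4-hydroxyphenyl, gives an at least 1.9-fold lower number from compound 3 to compound 4 (0.28 log units; that floor lies within the scatter). Set against the vinyl ester, the 2-(4-hydroxyphenyl)ethenyl ester gives an at least 1.9-fold lower number from compound 2 to compound 4 (0.28 log units; that floor lies within the scatter). Compound 4 is the first in the series to read as a number, while the others remain limits: the limit of > 10 ug/mL in this assay, at which 3 of the 4 values shown sit.

On these data alone, the true size of both steps stays open, since each rests on a limit and only a floor can be read. Also open, as far as these compounds go, is whether methoxy, an amine or a carboxylic acid on the same phenyl carbon would likewise give a number.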